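Furan in place of methylphenyl on a selenium-linked naphthoquinone

This account rests on a few compounds, and the source may have more. Where it says the series, first, only, none or still open, it means among the compounds named here.

Measured compounds:
Compound 1, `COc1ccc(Cn2nnnc2C(Nc2ccc([Se][Se]c3ccc(NC(c4ccco4)c4nnnn4Cc4ccc(OC)cc4OC)cc3)cc2)c2ccco2)c(OC)c1`, gives >= 100000 nM in a functional assay on MCF7 cells (Homo sapiens) for cytotoxicity, read by MTT assay, with a stated time of 48 h (on this read-out lower numbers stand for stronger inhibition and higher numbers for weaker inhibition), which is a limit of the assay rather than a number.
Compound 2, `CC1=C([Se]c2ccc(NCc3nnnn3C(C)(C)C)cc2)C(=O)c2ccccc2C1=O`, gives 42000 nM in this assay.
Compound 3, `CC1=C([Se]c2ccc(NC(c3ccc(C)cc3)c3nnnn3C(C)(C)C)cc2)C(=O)c2ccccc2C1=O`, gives >= 100000 nM in this assay, again a limit rather than a number.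

Compound 3 therefore stands at the weak end of what was measured; (the limit of >= 100000 nM in this assay, at which 2 of the 3 values shown sit). Going by the values given here, the one single-point comparison that was measured, an at least 2.3-fold higher number from compound 2 to compound 3 (0.37 log units; beyond the scatter), shows that adding the 4-methylphenyl group onto the saturated chain carbon weakened cytotoxicity at least modestly.

Compound 4, `CC1=C([Se]c2ccc(NC(c3ccco3)c3nnnn3C(C)(C)C)cc2)C(=O)c2ccccc2C1=O`, differs from compound 3 by furan-2-yl in place of 4-methylphenyl on a saturated chain carbon bound to an aromatic carbon and a nitrogen on an aromatic ring. Among the compounds with values here, no measured pair tests this exact swap. Compound 1 also carries furan-2-yl at a comparable position, on a different core, and sits at the same limit as compound 3. Nothing measured points toward a gain, and a number much below the limit would require a step larger than any seen here.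

Compound 4 is therefore expected to give 100000 nM, with a likely range from 40000 nM to 300000 nM. This estimate means a number no higher from compound 3 to compound 4 (the limit leaves the size open), that is, no change beyond the scatter is expected.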

Compound 4, half-maximal inhibitory concentration: >= 100000 nM
Compound 4 ended at the assay's limit (the forecaster's own chance of this, stated with the estimate: 60%); the middle value lies on the limit itself.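

In this assay, furan-2-yl on this saturated chain carbon, compared with the hydrogen it replaces, gives an at least 2.3-fold higher number from compound 2 to compound 4 (0.37 log units; beyond the scatter). The weakening seen with 4-methylphenyl is therefore not confined to that one group, since a five-membered aromatic ring with an oxygen at the same place also leaves the compound weaker than compound 2. The step between compound 3 and compound 4 cannot be read, so the two rings cannot be ranked, and the series now crowds at one end of the scale: the limit of >= 100000 nM in this assay, at which 3 of the 4 values shown sit.

From the compounds shown here alone, it remains open whether a group that is not an aromatic ring, such as a methyl group or a carboxylic acid on this carbon, would keep the cytotoxicity. Equally open, going by these compounds, is whether any group here could give a lower number than compound 2, at 42000 nM.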